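Arylpiperazine in place of urea on a quinoline-type alpha-1 ligand

The source may report more compounds than this note shows. Statements on the series, on what has been measured and on what is new or still open speak of the compounds shown alone.

Of the compounds shown here, two have been measured in an assay on brain for displacement of a labelled ligand from Adrenergic receptor alpha-1 (Rattus norvegicus); on this read-out lower numbers stand for stronger inhibition and higher numbers for weaker inhibition. Compound 1 `CCN(CC)c1cc(N)c2cc(OC)c(OC)cc2n1` carries a diethylamino group on the shared core and gives 2.93 nM. Compound 2 `CCCNC(=O)N1CCN(c2cc(N)c3cc(OC)c(OC)cc3n2)CC1` carries a piperazine bearing a propylcarbamoyl group on the same core and gives 0.44 nM. Of the two numbers, compound 2 has the lower one, and the gap to compound 1 lies beyond the scatter of this assay.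

The next compound, compound 3 `CCOc1ccnc(N2CCN(c3cc(N)c4cc(OC)c(OC)cc4n3)CC2)n1`, keeps the piperazine and the core of compound 2 and differs only at the ring nitrogen: 4-ethoxypyrimidin-2-yl in place of propylcarbamoyl on an amine nitrogen in a ring. Going by the values given here, no measured pair shows a step of this kind, so there is nothing to read it against directly. Since the core and the piperazine that go with the low number of compound 2 in this assay, 0.44 nM, stay in place, the expectation for compound 3 is a step of a 1.4-fold higher number from compound 2 to compound 3 (0.13 log units; within the scatter), within the scatter, with no clear direction. Compound 3 is accordingly estimated at 0.6 nM, with a range from 0.15 nM to 2.5 nM in this assay.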

Compound 3, inhibition constant: 0.42 nM
The estimate for compound 3 lay 1.4-fold (0.15 log units) above the measured number; the measured number falls inside the stated range.
By their numbers in this assay, from the lowest: compounds 3 and 2 (each within the scatter of the next); then compound 1.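

Going by these compounds alone, on the amine nitrogen in a ring, 4-ethoxypyrimidin-2-yl in place of propylcarbamoyl gives a 1.0-fold lower number from compound 2 to compound 3 (0.02 log units; within the scatter) in this assay, so this is the first read of the position itself, and it tolerates this exchange without a change beyond the scatter. Within the data shown here, the two groups have little in common by the counts: 6 heavy atoms with no ring leave, 9 heavy atoms with a six-membered aromatic ring enter, and the hydrogen-bond donor of propylcarbamoyl has no counterpart in 4-ethoxypyrimidin-2-yl, yet compound 2 and compound 3 cannot be told apart on this read-out. Nothing at hand bears on why these two groups read alike.

Open, on these data alone, is how much of any group on this nitrogen is needed, which a plain hydrogen, a small acetyl group or an unsubstituted phenyl ring would test, and whether a charged group such as a carboxylic acid is also tolerated there. Also open, as far as these compounds go, is whether the ethoxy group of compound 3 counts at all, which a hydrogen or a longer chain in its place would show.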